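Cytotoxicity notes on the tert-butoxy acetic acid urea series

A few compounds are considered here, and "the series" means these few. Any claim that something is new, unique, unknown or untested is made for them only; others in the source may bear on it.

Measured so far in an ADME assay on MT4 cells (Homo sapiens) for cytotoxicity, read by MTT assay; on this read-out lower numbers stand for higher toxicity in this test and higher numbers for lower toxicity in this test:
compound 1 `Cc1nc(NC(=O)NC2CCCCC2)c(C)c(C(OC(C)(C)C)C(=O)O)c1-c1ccc2c(c1C)CCCO2`: 11000 nM
compound 2 `Cc1nc(NC(=O)NC2CCCCC2)c(C)c(C(OC(C)(C)C)C(=O)O)c1-c1ccc(Cl)cc1`: 16000 nM
compound 3 `Cc1ccc(-c2c(C)nc(NC(=O)NC3CCOCC3)c(C)c2C(OC(C)(C)C)C(=O)O)cc1C`: 29000 nM

Compound 3 gives the highest number of the three; it sits within the scatter of compound 2 and beyond it only against compound 1. Among the measured compounds shown here, the one measured step, a 1.5-fold higher number from compound 1 to compound 2 (0.16 log units; within the scatter), changes the aryl group and stays within the scatter. Compound 4 `Cc1ccc(-c2c(C)nc(NC(=O)NC3CCCC3)c(C)c2C(OC(C)(C)C)C(=O)O)cc1C` differs from compound 3 by cyclopentyl in place of oxan-4-yl on an amide-type nitrogen. For the measured compounds named here, no measured step touches that position, so nothing bears directly on it. Compounds 1 and 2 carry a cyclohexyl there and give the lower two numbers, but they differ from compound 3 elsewhere as well. Compound 4 is therefore expected to stay close, a 1.5-fold lower number from compound 3 to compound 4 (0.16 log units; within the scatter), with the estimate 20000 nM in this assay, from 8000 nM to 50000 nM.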

Compound 4, half-maximal cytotoxic concentration: 8000 nM
Estimate against measurement, compound 4: 2.5-fold (0.40 log units) above; the range from low to high includes it.
By their numbers in this assay, from the lowest: compounds 4, 1, 2 and 3 (each within the scatter of the next, the first and the last beyond it).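

In this assay the substituent on the amide-type nitrogen is not silent: cyclopentyl in place of oxan-4-yl gives a 3.6-fold lower number from compound 3 to compound 4 (0.56 log units; beyond the scatter), a change at this position alone that moves toward higher toxicity in this test. Among the compounds shown here, the only earlier step, at the aryl group, stayed within the scatter. Nothing on hand accounts for the size of this step.

As far as these compounds go, the change alters ring size and the ring oxygen together, so which of the two carries the step remains open. An oxolan-3-yl or piperidin-4-yl group on the same nitrogen would bear on that question.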